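Swapping allyl for an ester chain in compound 4

The compounds below may be only part of what the source reports. "The series", "measured", "known", "first", "only" and "open" are said of these compounds alone.

- compound 1 `CCOC(=O)CCO/N=C(/c1ccc(OC)c(OC)c1OC)c1cccc2ccccc12`: 19600 nM
- compound 2 `C=CCC(O)(c1ccc(OC)c(OC)c1OC)c1cccc2ccccc12`: 10700 nM
- compound 3 `CCOC(=O)/C=C/CO/N=C(/c1ccc(OC)c(OC)c1OC)c1cccc2ccccc12`: 14000 nM

In a functional assay on A549 cells (Homo sapiens) for inhibition, read by sulforhodamine B assay, with a stated time of 48 h (a lower number here means a stronger inhibitor, a higher number a weaker inhibitor), compound 2 gives 10700 nM. This value lies within the scatter of the values of both other compounds, so the three cannot be ranked.

Compound 4 `CCOC(=O)C(C)C(O)(c1ccc(OC)c(OC)c1OC)c1cccc2ccccc12` has not yet been measured. It differs from compound 2 in one place: 1-(ethoxycarbonyl)ethyl in place of allyl on a saturated chain carbon bound to two aromatic carbons and an oxygen on a saturated carbon. In words, 1-(ethoxycarbonyl)ethyl stands in place of allyl on a saturated chain carbon bound to two aromatic carbons and an oxygen on a saturated carbon.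

Within the data shown here, no measured step covers this exchange directly. The only one available, a 1.4-fold lower number from compound 1 to compound 3 (0.15 log units; within the scatter), lies within the scatter, and it concerns a different chain, where 2-(ethoxycarbonyl)ethenyl replaces (ethoxycarbonyl)methyl. It bears on the question only loosely. Compound 1, at 19600 nM, and compound 3, at 14000 nM, both carry an ethoxycarbonyl group, yet both remain within the scatter of compound 2, which has none.

No step beyond the scatter is therefore expected in this assay, and the data favour no direction. The expected change is a 1.1-fold higher number from compound 2 to compound 4 (0.05 log units; within the scatter). For compound 4 the estimated value is 12000 nM, with an expected range from 5500 nM to 27000 nM.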

Compound 4, half-maximal inhibitory concentration: 4000 nM
For compound 4 the middle estimate is 3.0-fold (0.48 log units) above the measured one; the measured number lies below the stated range.
By their numbers in this assay, from the lowest: compound 4; then compounds 2, 3 and 1 (each within the scatter of the next).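

At the saturated chain carbon bound to two aromatic carbons and an oxygen on a saturated carbon, placing 1-(ethoxycarbonyl)ethyl in place of allyl gives, in this assay, a 2.7-fold lower number from compound 2 to compound 4 (0.43 log units; beyond the scatter), and this modest change is the only step among these compounds that lies beyond the scatter. The earlier comparison, a change within a different ester chain, had given no sign of a real difference, whereas this exchange shows that the number in this assay does respond to the group held at this position, here when a chain with two hydrogen-bond acceptors replaces one with none. The data shown offer no measured explanation for this step.

From the compounds shown here alone, this single exchange does not separate the part played by the ethoxycarbonyl group from that of the rest of the 1-(ethoxycarbonyl)ethyl chain, so it remains open whether a carboxylic acid, an amide or a longer chain at this position would keep, extend or lose the step. Going by these compounds, it also remains open whether the same exchange would give a comparable step in any other cell line.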